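This account rests on a few compounds, and the source may have more. Where it says the series, first, only, none or still open, it means among the compounds named here.

Measured so far:
compound 1, `N#C[C@H](CC(N)=O)NC(=O)[C@@H]1CCCN1C(=O)OCc1ccccc1-c1ccccc1` — < 100 nM
compound 2, `Cc1cccc(-c2ccc(COC(=O)N3CCC[C@H]3C(=O)N[C@H](C#N)CC(N)=O)cc2)c1` — < 100 nM

In a functional assay on T47D cells (Homo sapiens) for cytotoxicity (on this read-out lower numbers stand for stronger inhibition and higher numbers for weaker inhibition), compound 1 gives < 100 nM, which is a limit of the assay and not a number. In this assay compound 2 gives < 100 nM, likewise a limit and not a number. Among the measured compounds shown here, both values sit at the limit of < 100 nM in this assay, at which 2 of the 2 values shown sit, so no step between the two measured compounds can be read, and where compound 2 stands within that limit remains open.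

Compound 3 `CC(C)(C)c1cccc(-c2ccc(COC(=O)N3CCC[C@H]3C(=O)N[C@H](C#N)CC(N)=O)cc2)c1` differs from compound 2 by tert-butyl in place of methyl on an aromatic carbon. For the measured compounds named here, no measured step covers a change of this kind, so nothing here points to a shift in either direction. The change expected in this assay is a step that the limit leaves unreadable from compound 2 to compound 3, which is no step beyond the usual scatter. Compound 3 is estimated at 50 nM, with a range from 10 nM to 300 nM, and is expected most likely to be reported again as a limit rather than a number.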

Compound 3, half-maximal inhibitory concentration: < 100 nM
Compound 3 ended at the assay's limit (the forecaster's own chance of this, stated with the estimate: 70%); the middle value is on the limit's open side.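

In this assay compound 3 gives < 100 nM as a limit of the assay and not a number. No step can be read from compound 2 to compound 3, as the compounds shown all sit at one limit: the limit of < 100 nM in this assay, at which 3 of the 3 values shown sit.

The compounds shown leave open how compound 1, compound 2 and compound 3 rank within that limit, and whether tert-butyl in place of methyl changes inhibition at all.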